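A few compounds are considered here, and "the series" means these few. Any claim that something is new, unique, unknown or untested is made for them only; others in the source may bear on it.

Measured compounds in a physicochemical assay for solubility; a lower number here means a less soluble compound, a higher number a more soluble compound:
compound 1 `O=C(O)c1ccc(C(=O)/C(=C\c2ccc(F)c([N+](=O)[O-])c2)SCc2ccc(F)cc2)cc1` sits at a limit of this assay, < 1000 ug/mL
compound 2 `O=C(O)c1ccc(C(=O)/C(=C\c2ccc(Br)c([N+](=O)[O-])c2)SCc2ccc(Br)cc2)cc1` sits at a limit of this assay, < 1000 ug/mL
compound 3 `O=C(O)c1ccc(C(=O)/C(=C\c2ccc([N+](=O)[O-])c(F)c2)SCc2ccc(Br)cc2)cc1` sits at a limit of this assay, < 1000 ug/mL

Compound 3 stands at a limit in this assay, not at a number, and the two other values shown are limits as well, so compound 3 cannot be placed above or below them. Among the measured compounds shown here, the single step within the measured set, a step that the two limits leave unreadable from compound 2 to compound 3, gives no size because both of its ends sit at the limit described by the limit of < 1000 ug/mL in this assay, at which 3 of the 3 values shown sit.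

Compound 4 `O=C(O)c1ccc(C(=O)/C(=C\c2ccc(F)cc2[N+](=O)[O-])SCc2ccc(Br)cc2)cc1` differs from compound 3 in one place:
4-fluoro-2-nitrophenyl in place of 3-fluoro-4-nitrophenyl on a double-bonded chain carbon bound to a double-bonded chain carbon

For the measured compounds named here, no measured step reads a size for this kind of change; the step from compound 2 to compound 3 is the only one at hand and it is unreadable. With every shown value at the same limit, the step that the limit leaves unreadable from compound 3 to compound 4 is expected to stay within the scatter, and compound 4 is expected most likely to return a limit rather than a number in this assay. Compound 4 is estimated at 300 ug/mL, in the range 30 ug/mL to 1000 ug/mL.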

Compound 4, solubility: < 1000 ug/mL
Compound 4: no number, only a limit; the forecaster's own chance of this, stated with the estimate: 80%; the middle value lies beyond the limit too.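

In this assay compound 4 gives < 1000 ug/mL, which is a limit and not a number. No new step can be read from compound 2 or compound 3 to compound 4, as all values shown share one limit: the limit of < 1000 ug/mL in this assay, at which 4 of the 4 values shown sit.

The compounds shown leave open whether 4-fluoro-2-nitrophenyl and 3-fluoro-4-nitrophenyl differ at all in this assay.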